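Ethylamino for Ethoxy on the Shared Core

The source may hold more compounds than are shown below. What is called first, only, known or untested is meant among the compounds shown, and "the series" means these compounds.

The series rests on a shared core carried by compound 1 `CCOc1ccc2c(c1)OC(N)=C(C#N)C2c1cc(Br)c(OC)c(OC)c1`, compound 2 `COc1cc(OC)cc(C2C(C#N)=C(N)Oc3cc(OC)ccc32)c1` and compound 3 `COc1ccc2c(c1)OC(N)=C(C#N)C2c1ccccc1`. In a functional assay on T47D cells (Homo sapiens) for activation (a higher number here means that more compound is needed for the effect, a lower number that less compound is needed), compound 1 gives 64000000 nM. Compound 2 gives 15000000 nM in this assay, and compound 3 gives 360000000 nM. Compound 1 thus stands second highest of the three numbers, with compound 2 nearest at a lower number and compound 3 furthest at a higher one, both gaps beyond the usual scatter.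

Compound 4 `CCNc1ccc2c(c1)OC(N)=C(C#N)C2c1cc(Br)c(OC)c(OC)c1` has not yet been measured. It differs from compound 1 as follows: ethylamino in place of ethoxy on an aromatic carbon. Within the data shown here, no measured pair shows this exchange, so its effect in this assay is unknown from the data at hand.

Compound 4 is expected to land close to compound 1, with a step of a 1.3-fold lower number from compound 1 to compound 4 (0.11 log units; within the scatter) that is estimated to stay within or only slightly beyond the scatter. The estimate for compound 4 in this assay is 50000000 nM, with a range from 15000000 nM to 200000000 nM.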

Compound 4, half-maximal effective concentration: 14000000 nM
Compound 4: middle estimate off by 3.6-fold (0.55 log units), on the high side, outside the stated range (below it).
By their numbers in this assay, from the lowest: compounds 4 and 2 (each within the scatter of the next); then compound 1; then compound 3.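

Compound 4 gives the series its first change in a single place, and in this assay the result is a 4.6-fold lower number from compound 1 to compound 4 (0.66 log units; beyond the scatter) when ethylamino replaces ethoxy on the aromatic carbon. The earlier compounds shown here could not show that this position responds to the exchange of the ethoxy oxygen for the nitrogen of ethylamino, with the chain length unchanged and the rest of the core of compound 1 held fixed. Nothing measured here accounts for the direction or size of this step.

On these data alone, it remains open whether the step depends on the hydrogen-bond donor that ethylamino adds, which a dimethylamino group at the same place could help to test. As far as these compounds go, it is also open how methylamino or a longer chain such as propylamino would compare, and whether the exchange would give a similar step with the other aromatic substituents of compound 2 or compound 3.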